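A few compounds are considered here, and "the series" means these few. Any claim that something is new, unique, unknown or untested is made for them only; others in the source may bear on it.

Measured compounds:
compound 1 `COc1cc(N)c(Cl)cc1NC(=O)C1CCN(C/C=C/c2ccccc2)CC1`: in a functional assay on the whole organism for antagonist activity, with Mus musculus as the target (on this read-out lower numbers stand for an effect already at smaller amounts and higher numbers for an effect only at larger amounts of compound), compound 1 gives > 10 mg/kg, a limit of the assay and not a number.
compound 2 `COc1cc(N)c(Cl)cc1NC(=O)C1CCN(Cc2ccc(C)c(C)c2)CC1`: in this assay compound 2 gives > 8 mg/kg, again a limit and not a number.

Compound 2 therefore stands at the limit of > 8 mg/kg in this assay, at which 1 of the 2 values shown sits. Compound 1 stands at the limit of > 10 mg/kg in this assay, at which 1 of the 2 values shown sits. For the measured compounds named here, the one measured step, a step that the two limits leave unreadable from compound 1 to compound 2, has no readable size: both of its ends are limits. Compound 3 `COc1cccc(CN2CCC(C(=O)Nc3cc(Cl)c(N)cc3OC)CC2)c1` differs from compound 2 by 3-methoxyphenyl in place of 3,4-dimethylphenyl on a saturated chain carbon bound to an amine nitrogen in a ring. The measured step touches the same place but gives no size, so no direction can be drawn from it. Compound 3 is therefore expected to sit near the limits, estimated at 10 mg/kg with a range from 3 mg/kg to 30 mg/kg. The step expected from compound 2 to compound 3 is a step that the limit leaves unreadable from compound 2 to compound 3, none beyond the usual scatter, and most likely the assay reports again only a limit for compound 3.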

Compound 3, dose for half-maximal effect: > 4 mg/kg
Compound 3: no number, only a limit; the forecaster's own chance of this, stated with the estimate: 70%; the middle value is on the limit's open side.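

Compound 3 gives only a limit, as do compound 1 and compound 2, so no step among these three compounds can be read. The compounds shown leave open the actual dose at which each one reaches its half-maximal effect in this assay, and whether exchanging these groups changes that dose at all.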